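A Sulfonyl Swap and Its Expected Effect on Clearance

This account rests on a few compounds, and the source may have more. Where it says the series, first, only, none or still open, it means among the compounds named here.

Compound 1 `CN(C)S(=O)(=O)c1cncc(C#Cc2cc(Cl)ccc2OCC(=O)O)c1`: 13.3 mL/min/kg
Compound 2 `COCCNS(=O)(=O)c1ccc(C)c(C#Cc2cc(Cl)ccc2OCC(=O)O)c1`: 33.3 mL/min/kg

These two compounds were measured in an in vivo ADME assay on the whole organism (strain BALB/c) for pharmacokinetics, with Mus musculus as the target, read by LC-MS, at a dose of 5 mg/kg by the oral route; on this read-out higher numbers stand for fast clearance and lower numbers for slow clearance. Compound 2 gives 33.3 mL/min/kg, the higher of the two numbers and so the faster clearance. The gap to compound 1 lies beyond the usual scatter of repeated measurements. The two compounds differ in more than one place, however, so this gap cannot be traced to any single structural change.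

Compound 3 `Cc1ccc(S(C)(=O)=O)cc1C#Cc1cc(Cl)ccc1OCC(=O)O` differs from compound 2 in one place: methyl in place of (2-methoxyethyl)amino on a sulfonyl sulfur. Within the data shown here, no measured pair shows this change on its own, so any forecast is uncertain. Compound 1 also lacks the (2-methoxyethyl)amino group and gives 13.3 mL/min/kg, which offers weak support for expecting a modest fall rather than a rise. The estimated change is a 1.7-fold lower number from compound 2 to compound 3 (0.22 log units; within the scatter), a step that may not clear the scatter. For compound 3 the expected clearance is 20 mL/min/kg, with an estimated range from 9 mL/min/kg to 42 mL/min/kg.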

Compound 3, clearance: 23.3 mL/min/kg
The estimate for compound 3 lay 1.2-fold (0.07 log units) below the measured number; the range from low to high includes it.
By their numbers in this assay, from the lowest: compounds 1, 3 and 2 (each within the scatter of the next, the first and the last beyond it).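

Among these compounds, this is the first pair that isolates a single change at this spot, and it gives a direct reading of the swap. In this assay, putting methyl in place of (2-methoxyethyl)amino on a sulfonyl sulfur gives a 1.4-fold lower number from compound 2 to compound 3 (0.16 log units; within the scatter), so a group of 5 heavy atoms, with its hydrogen-bond donor and acceptor, gives way to a single carbon without a change in clearance that can be told from the scatter between repeated measurements. In this pair, then, the (2-methoxyethyl)amino group is not needed to keep clearance at the level of compound 2, and nothing measured here says why the two compounds read alike.

Among the compounds shown here, the gap between compound 1 and compound 2 is still not traced to any single change, since no step links those two compounds through one difference at a time. As far as these compounds go, how clearance responds to other groups on the same sulfonyl sulfur, such as a plain amino group or a longer chain, and whether the methyl swap reads the same on the core of compound 1, remain open.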